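This account rests on a few compounds, and the source may have more. Where it says the series, first, only, none or still open, it means among the compounds named here.

In a physicochemical assay for metabolic stability, read by HPLC, in phosphate buffer, at pH 7.4, tested at 10 uM (on this read-out lower numbers stand for a shorter-lived compound and higher numbers for a longer-lived compound), compound 1 `COc1nc2ccccc2n1C(=O)NCCCCc1ccccc1` gives > 2 h as its reading, and that is a limit of the assay and not a number. Among the measured compounds shown here, compound 2 `O=C(NCCCCc1ccccc1)n1cnc2ccccc21` gives 0.833 h as the only actual number so far. Compound 3 `CCCCCCNC(=O)n1cnc2ccccc21` keeps the core of compound 2 and alters the chain, with ethyl in place of phenyl on a saturated chain carbon, four bonds along the chain from an amide-type nitrogen as the difference: ethyl in place of phenyl on a saturated chain carbon, four bonds along the chain from an amide-type nitrogen. For the measured compounds named here, the only measured step is an at least 2.4-fold lower number from compound 1 to compound 2 (0.38 log units; beyond the scatter) and it comes with hydrogen in place of methoxy on an aromatic carbon, so it sets no size for a change in the chain. In this assay no step beyond the scatter is therefore expected. The expected change is a 1.0-fold lower number from compound 2 to compound 3 (0.02 log units; within the scatter) as estimated here. For compound 3 the estimate is 0.8 h with an expected range from 0.4 h to 1.7 h in this measurement.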

Compound 3, half-life: 0.983 h
Estimate against measurement, compound 3: 1.2-fold (0.09 log units) below; measured number inside the range.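

The chain now has a measured step of its own: in this assay, ethyl in place of phenyl gives a 1.2-fold higher number from compound 2 to compound 3 (0.07 log units; within the scatter). At this place, on a saturated chain carbon, four bonds along the chain from an amide-type nitrogen, replacing a six-membered aromatic ring of carbon only with a group that has no ring leaves the reading within the scatter. Among the compounds shown here, of the two places changed so far, only the one with hydrogen in place of methoxy on an aromatic carbon shows a step beyond the scatter, an at least 2.4-fold lower number from compound 1 to compound 2 (0.38 log units; beyond the scatter).

Compound 1 stands at a limit and has no actual number, so how far its reading lies from the others stays open: the limit of > 2 h in this assay, at which 1 of the 3 values shown sits. Whether a longer chain, or a chain ending in an amine or a carboxylic acid, would also stay within the scatter cannot be told from the compounds shown.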